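The compounds below may be only part of what the source reports. "The series", "measured", "known", "first", "only" and "open" are said of these compounds alone.

Series of lactam sulfonamides, all tested in an assay on isolated protein for inhibition of coagulation factor X (Oryctolagus cuniculus), tested at 1 uM; a higher number here means more inhibition at the concentration tested (going by the name of the read-out), a lower number less inhibition. Compound 1 `O=C1[C@@H](NS(=O)(=O)c2ccc(-c3ccon3)s2)CCN1Cc1cc2cc[nH]cc-2n1` gives 49%. Compound 2 `O=C1[C@@H](NS(=O)(=O)c2nc3cc(Cl)ccc3[nH]2)CCN1Cc1cc2cc[nH]cc-2n1` gives 21%; the change between them is 5-chloro-1H-benzimidazol-2-yl in place of 5-(1,2-oxazol-3-yl)thiophen-2-yl on a sulfonyl sulfur, and it produced a step of a number 28 percentage points lower from compound 1 to compound 2 (beyond the scatter). Compound 3 `O=C1[C@@H](NS(=O)(=O)c2ccc(-c3ccon3)s2)CCN1Cc1cc2[nH]cccc-2n1` gives 31%; its core differs from that of compound 1 as a group of 9 heavy atoms (7 carbon, 2 nitrogen; one five-membered aromatic ring with 1 hetero atom, one six-membered aromatic ring with 1 hetero atom) in place of a group of 9 heavy atoms (7 carbon, 2 nitrogen; one five-membered aromatic ring with 1 hetero atom, one six-membered aromatic ring with 1 hetero atom), on a saturated chain carbon bound to an amide-type nitrogen in a ring, with a step of a number 18 percentage points lower from compound 1 to compound 3 (beyond the scatter). Compound 4 `O=C1[C@@H](NS(=O)(=O)c2nc3cc(Cl)ccc3[nH]2)CCN1Cc1cc2[nH]cccc-2n1` is not yet measured in this assay. Its change from compound 3 is 5-chloro-1H-benzimidazol-2-yl in place of 5-(1,2-oxazol-3-yl)thiophen-2-yl on a sulfonyl sulfur, the same change as that from compound 1 to compound 2, at the same place. Going by the values given here, the earlier occurrence, a number 28 percentage points lower from compound 1 to compound 2 (beyond the scatter), is the only precedent, and the lower starting point of compound 3, 31%, leaves less room for the number to fall. A step of about a number 23 percentage points lower from compound 3 to compound 4 (beyond the scatter) is therefore expected for compound 4. Compound 4 is estimated at 8%, between 0% and 25%.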

Compound 4, a percentage reported as inhibition, at one concentration (the size of the read-out at that concentration, not a potency): 14%
Estimate against measurement, compound 4: 6 percentage points below; the range from low to high includes it.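

In this assay, 5-chloro-1H-benzimidazol-2-yl in place of 5-(1,2-oxazol-3-yl)thiophen-2-yl on the sulfonyl sulfur gives a number 17 percentage points lower from compound 3 to compound 4 (beyond the scatter), so the change carries over to the second core with the same direction and a size not distinguished from the earlier step: the same change on two cores in this assay, a number 28 percentage points lower (beyond the scatter) from compound 1 to compound 2 and a number 17 percentage points lower (beyond the scatter) from compound 3 to compound 4, 11 percentage points apart, within the scatter of two such steps. The core change, read with the 5-chloro-1H-benzimidazol-2-yl group in place, gives a number 7 percentage points lower from compound 2 to compound 4 (within the scatter), and this step is likewise not distinguished from its earlier occurrence: the same change on two cores in this assay, a number 18 percentage points lower (beyond the scatter) from compound 1 to compound 3 and a number 7 percentage points lower (within the scatter) from compound 2 to compound 4, 11 percentage points apart, within the scatter of two such steps. These two cores do not show that the change would carry over to any other core, and they do not explain the steps.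

Open, going by these compounds, is how a group carrying an amine or a carboxylic acid would read on the sulfonyl sulfur on either core.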